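The compounds below may be only part of what the source reports. "The series", "measured", "known", "first", "only" and "open" are said of these compounds alone.

In a physicochemical assay for solubility, with a stated time of 24 h, at pH 6.8 (a higher number here means a more soluble compound, a lower number a less soluble compound), compound 1 `CN(C)C(=O)c1c[nH]c2ccccc12` gives > 44 ug/mL, which is a limit of the assay and not a number. Compound 2 `O=C(Cn1ccccc1=O)Nc1cc2cccccc-2c1`, a structurally different compound, gives 2 ug/mL in this assay. Compound 3 `CN(C)C(=O)c1cn(C)c2ccccc12` differs from compound 1 by methyl in place of hydrogen on an aromatic nitrogen, with methyl in place of hydrogen on an aromatic nitrogen. For the measured compounds named here, no measured pair shows the size of such a change, so no step beyond the scatter is expected in this assay, in either direction. The expected change is a step that the limit leaves unreadable from compound 1 to compound 3. Compound 3 is estimated at 45 ug/mL, with an expected range of 15 ug/mL to 100 ug/mL.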

Compound 3, solubility: > 51 ug/mL
Compound 3 ended at the assay's limit; the forecaster's own chance of this, stated with the estimate: 55%; at least 1.1-fold (0.05 log units) between middle value and limit.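

In this assay, compound 1 and compound 3 both stand at limits of the assay, so no step can be read between them. The compounds shown leave open what size of change, if any, methyl in place of hydrogen on an aromatic nitrogen brings to solubility.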